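From chloro to methyl on the aromatic ring

The source may hold more compounds than are shown below. What is called first, only, known or untested is meant among the compounds shown, and "the series" means these compounds.

Compound 1 `Cn1nc(-c2ccc(F)cc2)n(C)c1=S`: 1 mg/kg
Compound 2 `Cn1nc(-c2ccc(Cl)cc2)n(C)c1=S`: 0.27 mg/kg
Compound 3 `Cc1ccc(-c2nn(C)c(=S)n2C)cc1`: not yet measured

In a functional assay on the whole organism with Mus musculus as the target (a higher number here means that more compound is needed for the effect, a lower number that less compound is needed), compound 2 holds the lower of the two numbers at 0.27 mg/kg. Compound 3 differs from compound 2 by one change: methyl in place of chloro on an aromatic carbon. For the measured compounds named here, only one measured step bears on this place: a 3.7-fold lower number from compound 1 to compound 2 (0.57 log units; beyond the scatter), for chloro in place of fluoro. That step shows the number moving with the group there, though no methyl has been measured. A modest rise is therefore expected, with an estimated step of a 2.2-fold higher number from compound 2 to compound 3 (0.35 log units; beyond the scatter). For compound 3 the estimated value is 0.6 mg/kg, with an expected range of 0.2 mg/kg to 1.8 mg/kg.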

Compound 3, dose for half-maximal effect: 4.2 mg/kg
For compound 3 the middle estimate is 7.0-fold (0.85 log units) below the measured one, and the stated range ends below it.
By their numbers in this assay, from the lowest: compound 2; then compound 1; then compound 3.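

In this assay the steps of a 16-fold higher number from compound 2 to compound 3 (1.19 log units; beyond the scatter) and a 4.2-fold higher number from compound 1 to compound 3 (0.62 log units; beyond the scatter) show that this aromatic carbon responds strongly to the group it carries, and more sharply than the earlier fluoro-to-chloro step suggested. Chloro and methyl have the same heavy-atom count and neither adds a hydrogen-bond donor or acceptor, so those counts do not separate the two groups. Nothing available accounts for the size of this step.

Bromo, methoxy or an amine on this aromatic carbon could each still fall anywhere relative to the three numbers. Going by these compounds, whether a longer chain such as ethyl would raise the number further than methyl also remains open.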